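From 4-methylbenzyl to isopropyl on the amine nitrogen

This account rests on a few compounds, and the source may have more. Where it says the series, first, only, none or still open, it means among the compounds named here.

Measured so far in a functional assay on HCT-15 cells (Homo sapiens) for inhibition, read by MTT assay, with a stated time of 72 h; on this read-out lower numbers stand for stronger inhibition and higher numbers for weaker inhibition:
Compound 1 `COc1cc(Oc2cccc(Nc3ccccc3)c2)cc(OC)c1CNCc1ccc(C)cc1`: 5400 nM
Compound 2 `COc1ccc([C@@H](C)NCc2c(OC)cc(Oc3cccc(Nc4ccccc4)c3)c(OC)c2OC)cc1`: 4690 nM

Only these two compounds have been measured, and their numbers lie within the scatter of each other, so compound 1 cannot be ranked against compound 2. Compound 3 `COc1cc(Oc2cccc(Nc3ccccc3)c2)cc(OC)c1CNC(C)C` keeps the core of compound 1 and carries isopropyl in place of 4-methylbenzyl on an amine nitrogen. Among the measured compounds shown here, the data hold no measured step for this change, or for any other single change, so the expectation rests on the structural change alone and remains uncertain. In this assay, a moderate step towards weaker inhibition, beyond the scatter, is expected: a 2.2-fold higher number from compound 1 to compound 3 (0.35 log units; beyond the scatter). Compound 3 is estimated at 12000 nM, with an expected range of 5000 nM to 30000 nM.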

Compound 3, half-maximal inhibitory concentration: > 20000 nM
Compound 3 was reported as a limit (the forecaster's own chance of this, stated with the estimate: 15%); middle value at least 1.6-fold (0.22 log units) away from the limit.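

In this assay, compound 3 is reported only as a limit, > 20000 nM. Isopropyl in place of 4-methylbenzyl on the amine nitrogen gives an at least 3.7-fold higher number from compound 1 to compound 3 (0.56 log units; beyond the scatter), the first measured step in the series and the first sign that the group on this nitrogen matters in this assay. The step gives only a lower bound on the size of the change, set by one of the values shown: the limit of > 20000 nM in this assay, at which 1 of the 3 values shown sits.

The compounds shown do not say whether a plain benzyl, a cyclohexylmethyl or a longer chain such as n-butyl on this amine nitrogen would keep the number of compound 1. Nor do they separate the loss of the aromatic ring from the loss of heavy atoms, since both change together in this single step.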